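The source may hold more compounds than are shown below. What is called first, only, known or untested is meant among the compounds shown, and "the series" means these compounds.

In an ADME assay on L6 cells (Rattus norvegicus) for cytotoxicity, read by resazurin assay, with a stated time of 72 h (on this read-out lower numbers stand for stronger inhibition and higher numbers for weaker inhibition), compound 1 `Cc1ccccc1C(O)(c1ccc(Cl)cc1)c1cccnc1` gives 82000 nM and compound 2 `OC(c1ccc(Cl)cc1)(c1cccnc1)c1ccccc1C(F)(F)F` gives 59300 nM so the two stand within the scatter of each other. Compound 3 `OC(c1ccc(Cl)cc1)(c1cccnc1)c1cncs1` is not yet measured and differs from compound 1 by 1,3-thiazol-5-yl in place of 2-methylphenyl on a saturated chain carbon bound to two aromatic carbons and an oxygen on a saturated carbon in one place: 1,3-thiazol-5-yl in place of 2-methylphenyl on a saturated chain carbon bound to two aromatic carbons and an oxygen on a saturated carbon. Among the measured compounds shown here, the only measured step, a 1.4-fold lower number from compound 1 to compound 2 (0.14 log units; within the scatter) for trifluoromethyl in place of methyl on an aromatic carbon, bears only loosely on this change, so no step beyond the scatter is expected in this assay here. For compound 3 the expected value is 70000 nM with an estimated range from 30000 nM to 150000 nM in this read-out. The estimated change is a 1.2-fold lower number from compound 1 to compound 3 (0.07 log units; within the scatter) and stays an expectation until measured.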

Compound 3, half-maximal inhibitory concentration: > 100000 nM
Compound 3: a limit, no number (the forecaster's own chance of this, stated with the estimate: 10%); middle value at least 1.4-fold (0.15 log units) away from the limit.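

In this assay compound 3 gives > 100000 nM, which is a limit of the assay and not a number. Exchanging the six-membered carbon ring at this position for a five-membered aromatic ring with 2 hetero atoms gives an at least 1.2-fold higher number from compound 1 to compound 3 (0.08 log units; that floor lies within the scatter), so this position, unlike the methyl to trifluoromethyl change, has now been tested with a different ring. The true size of this step cannot be read, and only its floor is known: the limit of > 100000 nM in this assay, at which 1 of the 3 values shown sits.

Going by these compounds, how far compound 3 lies past the limit remains open. Also open, on these data alone, is whether an amine or a carboxylic acid at this position would move the number beyond the scatter in this assay.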